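The source may report more compounds than this note shows. Statements on the series, on what has been measured and on what is new or still open speak of the compounds shown alone.

Of the compounds shown here, two on a shared core have been tested so far, compound 1 (`COC/C1=C/C[C@](C)(CCC=C(C)C)/C=C/[C@@H](OC(=O)C=C(C)C)[C@](C)(OC)/C=C/C1=O`) and compound 2 (`CC(C)=CCC[C@]1(C)/C=C/[C@@H](OC(=O)C=C(C)C)[C@](C)(O)/C=C/C(=O)/C(C(=O)O)=C\C1`). In a functional assay on A549 cells (Homo sapiens) for antiproliferative activity, read by MTT assay, with a stated time of 48 h (a higher number here means a weaker inhibitor, a lower number a stronger inhibitor), compound 1 gives 4180 nM as its half-maximal inhibitory concentration. Compound 2 gives > 10000 nM in this assay and this is a limit of the assay, not a number. Compound 2 therefore offers no exact starting point for the next step.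

Compound 3 (`CC(C)=CCC[C@]1(C)/C=C/[C@@H](OC(=O)C=C(C)C)[C@](C)(O)/C=C/C(=O)/C(CN2CCN(C)CC2)=C\C1`) carries (4-methylpiperazin-1-yl)methyl in place of carboxy on a double-bonded ring carbon, and the shared core is otherwise unchanged ((4-methylpiperazin-1-yl)methyl in place of carboxy on a double-bonded ring carbon). Within the data shown here, no measured pair shows what this exchange does, so any forecast is uncertain. A moderate shift in this assay towards stronger inhibition is expected, with compound 3 landing in the region where compound 1 sits at 4180 nM on this read-out. The expected move is an at least 2.8-fold lower number from compound 2 to compound 3 (0.45 log units; beyond the scatter) in the direction of lower numbers. For compound 3 the estimated value is 3500 nM with an expected range from 1000 nM to 10000 nM in this cell test.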

Compound 3, half-maximal inhibitory concentration: 940 nM
Beside the measured number, compound 3's estimate is 3.7-fold (0.57 log units) above it, and the stated range ends above it.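

The double-bonded ring carbon, three ring bonds from the ring atom that bears a 4-methylpent-3-en-1-yl group, proves to be a place where the choice of group matters in this assay: exchanging carboxy for (4-methylpiperazin-1-yl)methyl gives an at least 10-fold lower number from compound 2 to compound 3 (1.02 log units; beyond the scatter). This is the only pair shown that differs in one place, and its step lies beyond the usual scatter, which the earlier compounds could not show about this change. Compound 2 stands at a limit of the assay and not at a number, so the step has a limit as its starting point: the limit of > 10000 nM in this assay, at which 1 of the 3 values shown sits.

The compounds shown leave open whether the ring of the (4-methylpiperazin-1-yl)methyl group is needed, or whether an open-chain amine such as dimethylaminomethyl, or a morpholin-4-ylmethyl group with oxygen in place of the methylated nitrogen, would serve on the same carbon. They also leave open how a methyl ester or a primary amide would stand there, and whether the same exchange would give a similar step on a core that carries methoxy in place of the hydroxy group.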